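A few compounds are considered here, and "the series" means these few. Any claim that something is new, unique, unknown or untested is made for them only; others in the source may bear on it.

Measured so far in an assay on A549 cells with Cystic fibrosis transmembrane conductance regulator variant F508del (Homo sapiens) as the target, read by fluorescence, with a stated time of 25 min; on this read-out lower numbers stand for smaller maximal responses and higher numbers for larger maximal responses:
compound 1 `NC(=O)CN1CCN(c2nc(-c3ccccn3)nc3c2CN(Cc2ccccc2)CC3)CC1`: "not active" (no number reported)
compound 2 `CN1CCN(CCCNc2nc(-c3ccccn3)nc3c2CN(Cc2ccccc2)CC3)CC1`: "not active" (no number reported)
compound 3 `CN(C)CCN1CCN(c2nc(-c3ccccn3)nc3c2CN(Cc2ccccc2)CC3)CC1`: 57%

The three compounds share one core. Only compound 3 has returned a number in this assay; compound 1 and compound 2 came back without a reported value. No step between measured compounds can therefore be drawn, and where compound 3 stands can be said only as the single number shown in the series.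

Compound 4 `CN(C)CCN1CCN(c2nc(-c3ccccn3)nc3c2CN(Cc2ccc(F)cc2)CC3)CC1` differs from compound 3 in one place: fluoro in place of hydrogen on an aromatic carbon. Read one bond further out, the change is benzyl to 4-fluorobenzyl, and the remainder of the molecule, including the core, is unchanged.

For the measured compounds named here, with no measured step to lean on, the expectation for this assay rests on the small size of the change. The expected step is a number 2 percentage points lower from compound 3 to compound 4 (within the scatter), that is, none beyond the usual scatter in either direction.

Compound 4 is estimated at 55% in this assay, with a range from 35% to 72%. A run that reports no number for compound 4, as happened for compound 1 and compound 2, remains a real possibility.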

Compound 4, largest response reached (Emax), in percent of the reference or control that the assay uses: "not active" (no number reported)
Nothing numeric was reported for compound 4; the estimate stays without a comparison.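

For the compounds shown here, compound 3 carries a number and compound 4 has none, so no step between them can be read. The compounds shown leave open whether benzyl to 4-fluorobenzyl itself accounts for that difference in outcome. No supporting evidence bears on this result.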